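The source may hold more compounds than are shown below. What is called first, only, known or untested is meant among the compounds shown, and "the series" means these compounds.

Working notes on the series. Compound 3 `COC(=O)Cc1c(C)nc2c(OCc3ccccc3)cccn12` is the compound with the lowest of the three numbers seen so far: in a functional assay on the whole organism with Rattus norvegicus as the target, with a stated time of 4 h, at a dose of 40 mg/kg by the intraperitoneal route (a lower number here means less inhibition, a higher number more inhibition at the dose given (going by the name of the read-out)), compound 3 gives 23%. Compound 2 `Cc1nc2c(OCc3ccccc3)cccn2c1Br` stands nearest, for in this assay compound 2 gives 26%, and a number 3 percentage points lower from compound 2 to compound 3 (within the scatter). Compound 1 `Cc1nc2c(OCc3ccccc3)cccn2c1CS(C)(=O)=O` stands furthest away, since in this assay compound 1 gives 61%; the steps of a number 35 percentage points lower from compound 1 to compound 2 (beyond the scatter) and a number 38 percentage points lower from compound 1 to compound 3 (beyond the scatter) are both large.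

Compound 4 `CCCCC(=O)OCc1c(C)nc2c(OCc3ccccc3)cccn12` is not yet measured. It differs from compound 3 in one place: (butylcarbonyl)oxy in place of methoxycarbonyl on a saturated chain carbon bound to an aromatic carbon.

Among the compounds with values here, of the measured steps, only the one from compound 1 to compound 3 touches the same saturated chain carbon, and there methoxycarbonyl in place of methylsulfonyl gave a large drop; nothing measured speaks to (butylcarbonyl)oxy itself. The step from compound 2 to compound 3 shows that two different groups at this part of the core can sit within the scatter of each other. Within the data shown here, with no measured precedent for the entering group, the expectation for compound 4 is a step of a number 2 percentage points higher from compound 3 to compound 4 (within the scatter) from compound 3, that is none beyond the scatter. For compound 4 in this assay the estimate is therefore 25%, expected within 5% to 50%.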

Compound 4, a percentage reported as inhibition, in the whole organism at one dose (the size of the read-out at that dose, not a potency): 45%
Beside the measured number, compound 4's estimate is 20 percentage points below it; the range from low to high includes it.
By their numbers in this assay, from the lowest: compounds 3 and 2 (each within the scatter of the next); then compound 4; then compound 1.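

Within the data shown here, on the saturated chain carbon bound to an aromatic carbon, the earlier compounds showed only a loss on leaving methylsulfonyl, whereas (butylcarbonyl)oxy in place of methoxycarbonyl recovers part of it in this assay, with a number 22 percentage points higher from compound 3 to compound 4 (beyond the scatter) and with a number 16 percentage points lower from compound 1 to compound 4 (beyond the scatter) still standing against it. Compound 4 therefore takes a middle place, and ((butylcarbonyl)oxy)methyl in place of bromo gives a number 19 percentage points higher from compound 2 to compound 4 (beyond the scatter), so this position can separate groups that carry no sulfonyl, which the pair of compound 2 and compound 3, within the scatter of each other, could not show. The change enlarges the group from the count of 4 heavy atoms to 7 with the same count of acceptors, yet nothing at hand bears on why the number moves.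

The compounds shown leave open whether the gain follows the butyl chain or the reversed ester link, which a (methylcarbonyl)oxy group on the same carbon would separate. Also open, going by these compounds, is how a free hydroxymethyl, a carboxylic acid, an amide or a longer chain than butyl would stand at this position in this assay.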